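The source may report more compounds than this note shows. Statements on the series, on what has been measured and on what is new or still open speak of the compounds shown alone.

Compound 1 `Fc1ccc(-c2nn3ccc(N4CCCC4)cc3c2-c2ccnc(NC3CCCC3)n2)cc1` and compound 2 `CC(C)Nc1ccn2nc(-c3ccc(F)cc3)c(-c3ccnc(NC4CCCC4)n3)c2c1` share one core and differ in a single group. In an ADME assay on Vero cells (Chlorocebus sabaeus) for cytotoxicity (a lower number here means that less compound is tolerated, a higher number that more compound is tolerated), compound 1 gives > 40000 nM, which is a limit of the assay rather than a number. In this assay compound 2 gives > 40000 nM, again a limit and not a number. The step that the two limits leave unreadable from compound 1 to compound 2 is therefore not readable in size or direction. Compound 2 thus stands exactly where every value shown stands: the limit of > 40000 nM in this assay, at which 2 of the 2 values shown sit.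

Compound 3 `CC(C)Nc1cc(NC(C)C)n2nc(-c3ccc(F)cc3)c(-c3ccnc(NC4CCCC4)n3)c2c1` carries the change (isopropylamino in place of hydrogen on an aromatic carbon). For the measured compounds named here, the only measured step, a step that the two limits leave unreadable from compound 1 to compound 2, bears on this change but offers no readable size, so it can neither set a magnitude nor a direction for the added group. With both measured compounds at the limit, no step beyond the usual scatter is expected for compound 3 in this assay. Compound 3 is therefore expected to give about 60000 nM, within a range of 25000 nM to 150000 nM, and most likely to be reported only as a limit once more. The expected step, a step that the limit leaves unreadable from compound 2 to compound 3, is an estimate rather than a measurement.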

Compound 3, half-maximal cytotoxic concentration: > 40000 nM
Compound 3: a limit, no number (the forecaster's own chance of this, stated with the estimate: 80%); the middle value does not contradict the limit.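

For the compounds shown here, compound 2 and compound 3 both give only a limit in this assay, so no step between them can be read, in size or in direction. The three compounds share one result: the limit of > 40000 nM in this assay, at which 3 of the 3 values shown sit. Still open, on these data alone, is the concentration at which compound 1, compound 2 or compound 3 would harm these cells, and whether the added isopropylamino group changes it.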